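Working notes: from compound 2 to compound 3

The source may report more compounds than this note shows. Statements on the series, on what has been measured and on what is new or still open speak of the compounds shown alone.

- compound 1 `CCOC(=O)c1c(C)nc(-c2ccc(C#N)cc2)n1OC`: 13400 nM
- compound 2 `CCOC(=O)c1[nH]c(-c2cccc(C#N)c2)nc1C`: > 30000 nM

All values come from a functional assay on a cell-free system (plasma, Oryctolagus cuniculus) for inhibition, with stated times of 5 min, 1 min and 6 min; on this read-out higher numbers stand for weaker inhibition and lower numbers for stronger inhibition. Compound 2 has no number, only the limit > 30000 nM.

Compound 3 `CCOC(=O)c1c(C)nc(-c2cccc(C#N)c2)n1OCCCO` differs from it by 3-hydroxypropoxy in place of hydrogen on an aromatic nitrogen, with 3-hydroxypropoxy in place of hydrogen on an aromatic nitrogen. The expected change is an at least 2.1-fold lower number from compound 2 to compound 3 (0.33 log units; beyond the scatter), a modest move towards stronger inhibition. Among the measured compounds shown here, that expectation rests on compound 1, the only measured compound with a number (13400 nM). Compound 3 is estimated at 14000 nM (range 5000 nM to 30000 nM).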

Compound 3, half-maximal inhibitory concentration: 11400 nM
Compound 3: middle estimate off by 1.2-fold (0.09 log units), on the high side, within the range that was stated.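

In this assay, 3-hydroxypropoxy in place of hydrogen on an aromatic nitrogen gives an at least 2.6-fold lower number from compound 2 to compound 3 (0.42 log units; beyond the scatter). Among the compounds shown here, this is the first reading at this position: the nitrogen can carry this chain, and the 3-cyanophenyl compound then gives a number rather than a limit. The true size of the step stays unknown, as compound 2 has only a limit: the limit of > 30000 nM in this assay, at which 1 of the 3 values shown sits.

Still open, on these data alone, is whether the chain's terminal hydroxyl matters to this gain. An amine or a carboxylic acid at the chain end, or a longer chain on this nitrogen, would test that.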